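Fluoro on the aryl ring of the propargyl amide

The source may hold more compounds than are shown below. What is called first, only, known or untested is meant among the compounds shown, and "the series" means these compounds.

Compound 2 `C#CCNC(=O)/C(C)=C(\C)c1ccccc1` carries a terminal alkyne on the amide nitrogen and an unsubstituted phenyl ring. In a functional assay on the whole organism (strain Icem-CET (SPF Caw)) for inhibition, with Mus musculus as the target, with a stated time of 30 min (on this read-out lower numbers stand for an effect already at smaller amounts and higher numbers for an effect only at larger amounts of compound), compound 2 gives 45.3 mg/kg, the highest of the two numbers available. The nearest value belongs to compound 1 `C/C(C(=O)NC1CC1)=C(/C)c1ccc(F)cc1`, which in this assay gives 25 mg/kg; the two values lie within the scatter of each other, and since compound 1 differs from compound 2 at both the amide substituent and the aromatic ring, no single step can be read from this pair.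

Compound 3 `C#CCNC(=O)/C(C)=C(\C)c1ccc(F)cc1` is the next entry: fluoro in place of hydrogen on an aromatic carbon. For the measured compounds named here, no measured pair isolates this change in this assay. Going by the values given here, the only fluorinated compound, compound 1, gives 25 mg/kg, which does not separate from compound 2 beyond the scatter, so for compound 3 no step beyond the scatter is expected, with at most a slight lean toward a smaller number. Compound 3 is accordingly expected at 35 mg/kg in this assay, with a range from 17 mg/kg to 70 mg/kg. The estimated step of a 1.3-fold lower number from compound 2 to compound 3 (0.11 log units; within the scatter) is expected to stay within the scatter.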

Compound 3, dose for half-maximal effect: 22.8 mg/kg
Beside the measured number, compound 3's estimate is 1.5-fold (0.19 log units) above it; the measured number falls inside the stated range.
By their numbers in this assay, from the lowest: compounds 3, 1 and 2 (each within the scatter of the next).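

Fluoro in place of hydrogen on the aromatic carbon para to a large group now has a measured pair of its own: in this assay the change gives a 2.0-fold lower number from compound 2 to compound 3 (0.30 log units; within the scatter), at the edge of the usual scatter but still inside it, so this pair alone does not establish a real difference at this position. With the fluoro kept, propargyl in place of cyclopropyl on the amide-type nitrogen gives a 1.1-fold lower number from compound 1 to compound 3 (0.04 log units; within the scatter), so in this assay the two nitrogen substituents cannot be told apart on the fluorinated compounds, a comparison that the earlier pair of compound 1 and compound 2 could not provide. No measurement on these compounds bears on why either step has the size it has.

Both places therefore remain without a step beyond the scatter, and the three compounds cover only hydrogen and fluoro on the aromatic carbon and only propargyl and cyclopropyl on the nitrogen. On these data alone, how a chloro or methoxy group at that aromatic position, or a longer chain or a free amine on the amide-type nitrogen, would read in this assay stays open.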